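Trimming the Benzyl Group of a Weak Inhibitor

The compounds below may be only part of what the source reports. "The series", "measured", "known", "first", "only" and "open" are said of these compounds alone.

Compound 1 `Cc1nc(Cc2ccccc2)n2c(O)nncc12` was tested in a functional assay for inhibition, with Homo sapiens as the target; on this read-out higher numbers stand for weaker inhibition and lower numbers for stronger inhibition. In this assay compound 1 gives > 48000 nM, which is a limit of the assay rather than a measured number. Two close relatives were tested the same way. Compound 2 `Oc1nncc2c(Br)nc(Cc3ccccc3)n12` carries bromo in place of methyl on an aromatic carbon, and in this assay compound 2 gives > 48000 nM, again a limit. Compound 3 `CCCc1nc(C)c2c(C)nnc(SC)n12` gives > 48000 nM in this assay, also a limit. For the measured compounds named here, the only step that can be traced, a step that the two limits leave unreadable from compound 1 to compound 2, stays unreadable because the limit of > 48000 nM in this assay, at which 3 of the 3 values shown sit, places every value shown at the same limit.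

Compound 4 `CCc1nc(C)c2cnnc(O)n12` differs from compound 1 in one place: methyl in place of phenyl on a saturated chain carbon bound to an aromatic carbon. Going by the values given here, no measured step alters the group on this saturated chain carbon, so none bears directly on the change. Among the compounds with values here, all that is known is that compound 1 and both of its relatives sit at the limit, which gives no direction and no size for the step. The estimate for compound 4 in this assay is therefore 100000 nM, with an expected range from 30000 nM to 400000 nM. This estimate means a step that the limit leaves unreadable from compound 1 to compound 4, expected to stay within the scatter.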

Compound 4, half-maximal inhibitory concentration: > 48000 nM
Compound 4 gave a limit, no number (the forecaster's own chance of this, stated with the estimate: 90%); the middle value lies beyond the limit too.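

The step from compound 1 to compound 4 cannot be read, because both compounds give only a limit, not a number: the limit of > 48000 nM in this assay, at which 4 of the 4 values shown sit. The compounds shown leave open whether methyl in place of phenyl changes inhibition at all, and which change to the shared core would give a measurable value in this assay.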